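Ethoxy in place of 4-methylphenyl: working notes

The source may report more compounds than this note shows. Statements on the series, on what has been measured and on what is new or still open speak of the compounds shown alone.

Measured in an ADME assay on L1210/0 cells (Mus musculus) for cytotoxicity, with a stated time of 48 h; a lower number here means a stronger inhibitor, a higher number a weaker inhibitor:
- compound 1 `Cc1ccc(-c2ncnc3c2ncn3C[C@@H]2C[C@H](CO)c3ccccc32)cc1`: 15400 nM
- compound 2 `CC1(C)[C@@H](Cn2nnc3c(N)nc(N)nc32)CC[C@@]1(C)CO`: > 200000 nM, a limit and not a number
- compound 3 `O=C1O/C(=C\Cn2cc(I)c(=O)[nH]c2=O)C(OCc2ccccc2)=C1OCc1ccccc1`: 7500 nM

Of the two true numbers, compound 1 holds the higher one, and compound 3 lies lower by a margin just beyond the usual scatter.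

Compound 4 `CCOc1ncnc2c1ncn2C[C@@H]1C[C@H](CO)c2ccccc21` has ethoxy in place of 4-methylphenyl on an aromatic carbon of the core of compound 1 (ethoxy in place of 4-methylphenyl on an aromatic carbon). Within the data shown here, no measured pair isolates this change, so the expectation is loose and starts from compound 1 at 15400 nM. The expected step of a 2.6-fold higher number from compound 1 to compound 4 (0.41 log units; beyond the scatter) is a moderate one towards a higher number in this assay. For compound 4 the estimated value is 40000 nM, with an expected range of 12000 nM to 130000 nM.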

Compound 4, half-maximal inhibitory concentration: > 200000 nM
Compound 4: a limit, no number (the forecaster's own chance of this, stated with the estimate: 15%); middle value at least 5.0-fold (0.69 log units) from the limit.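

Among these compounds, at this position, on an aromatic carbon of the core, ethoxy in place of 4-methylphenyl gives an at least 12-fold higher number from compound 1 to compound 4 (1.11 log units; beyond the scatter) in this assay, the first step between compounds that differ in one place. Compound 4 gives > 200000 nM as a limit of the assay and not a number, so the step is only a lower bound: the limit of > 200000 nM in this assay, at which 2 of the 4 values shown sit.

From the compounds shown here alone, whether an amine or a longer alkoxy chain on this carbon would give a number closer to compound 1 stays open. So does whether the step follows the loss of the carbon ring or the entry of the oxygen.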